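Trading a Cyano-Methylphenyl Group for a Dimethylpyridinyl Group

The source may report more compounds than this note shows. Statements on the series, on what has been measured and on what is new or still open speak of the compounds shown alone.

Compound 1 `COc1ccc(-c2c(C)nn(-c3nc(-c4ccc(Cl)c(Cl)c4)c(SC(C)C)s3)c2C(=O)O)cc1`: 2100 nM
Compound 2 `Cc1cc(Cl)cc(-c2c(C)nn(-c3nc(-c4ccc(Cl)c(Cl)c4)c(SC(C)C)s3)c2C(=O)O)c1`: 663 nM
Compound 3 `Cc1cc(C#N)cc(-c2c(C)nn(-c3nc(-c4ccc(Cl)c(Cl)c4)c(SC(C)C)s3)c2C(=O)O)c1`: 4800 nM

Three compounds share one core and differ only in the aromatic group attached to it. In a functional assay on BJAB cells (Homo sapiens) for antiproliferative activity, with a stated time of 4 days (on this read-out higher numbers stand for an effect only at larger amounts of compound and lower numbers for an effect already at smaller amounts), compound 3 gives the highest of the three numbers. The steps show why: a 3.2-fold lower number from compound 1 to compound 2 (0.50 log units; beyond the scatter), while a 2.3-fold higher number from compound 1 to compound 3 (0.36 log units; beyond the scatter) and a 7.2-fold higher number from compound 2 to compound 3 (0.86 log units; beyond the scatter).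

Compound 4 `Cc1cc(-c2c(C)nn(-c3nc(-c4ccc(Cl)c(Cl)c4)c(SC(C)C)s3)c2C(=O)O)cc(C)n1` has not yet been measured. The change from compound 3 is 2,6-dimethylpyridin-4-yl in place of 3-cyano-5-methylphenyl on an aromatic carbon. Among the compounds with values here, no measured step introduces a ring nitrogen in this position, so the only guidance comes from the steps above: a chloro-bearing ring gave the lowest number, and the cyano-bearing and methoxy-bearing rings gave higher ones. Compound 4 is therefore expected to sit near compound 3, with at most a modest change in either direction, which means an expected step of a 1.4-fold lower number from compound 3 to compound 4 (0.14 log units; within the scatter). The estimate for compound 4 in this assay is 3500 nM, with a likely range from 1000 nM to 12000 nM.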

Compound 4, half-maximal effective concentration: 580 nM
For compound 4 the middle estimate is 6.0-fold (0.78 log units) above the measured one, outside the stated range (below it).
By their numbers in this assay, from the lowest: compounds 4 and 2 (each within the scatter of the next); then compound 1; then compound 3.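

Putting 2,6-dimethylpyridin-4-yl in place of 3-cyano-5-methylphenyl gives an 8.3-fold lower number from compound 3 to compound 4 (0.92 log units; beyond the scatter) in this assay, which shows that this position accepts an aromatic ring with a nitrogen in it. Measured against the other two groups, the same ring gives a 1.1-fold lower number from compound 2 to compound 4 (0.06 log units; within the scatter) from 3-chloro-5-methylphenyl and a 3.6-fold lower number from compound 1 to compound 4 (0.56 log units; beyond the scatter) from 4-methoxyphenyl, so here it matches the chloro-bearing ring and not the cyano-bearing one. Nothing available explains what lies behind these differences.

The compounds shown leave open whether the ring nitrogen or the two methyl groups account for the result, as no compound here has one without the other. A pyridinyl group with no methyl groups, or a plain phenyl group, would help to separate the two.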